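The source may hold more compounds than are shown below. What is called first, only, known or untested is meant among the compounds shown, and "the series" means these compounds.

In a functional assay on MCF7 cells (Homo sapiens) for antiproliferative activity, read by sulforhodamine B assay, with a stated time of 3 days (on this read-out higher numbers stand for weaker inhibition and lower numbers for stronger inhibition), compound 1 (`c1ccc(Oc2ncnc3c2ncn3C2COc3ccccc3CO2)cc1`) gives 24700 nM and compound 2 (`CSc1ncnc2c1ncn2C1COc2ccccc2CO1`) gives 24000 nM while compound 3 (`c1ccc(Oc2ncnc3ncn(C4COc5ccccc5CO4)c23)cc1`) gives 21100 nM on the same read-out. Compound 3 stands within the scatter of both other values, so the three compounds cannot be put in any order.

The next change leads from compound 3 to compound 4 (`c1ccc(Sc2ncnc3ncn(C4COc5ccccc5CO4)c23)cc1`) and puts phenylsulfanyl in place of phenoxy on an aromatic carbon. For the measured compounds named here, the only measured step that touches this exchange is a 1.0-fold lower number from compound 1 to compound 2 (0.01 log units; within the scatter) with methylsulfanyl in place of phenoxy on an aromatic carbon. That step also removes phenoxy, but it enters a different group, and compound 1 is an isomer of compound 3 with the same pieces joined differently. Going by the values given here, it therefore gives only loose guidance, and no measured step shows phenylsulfanyl itself.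

With that single flat step as the guide, no change beyond the scatter is expected in this assay and no direction can be argued. The expected step is a 1.1-fold lower number from compound 3 to compound 4 (0.02 log units; within the scatter) and it is estimated to stay within the scatter. For compound 4 the estimate is 20000 nM with an expected range from 9000 nM to 40000 nM for a repeat measurement.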

Compound 4, half-maximal inhibitory concentration: 15600 nM
The estimate for compound 4 lay 1.3-fold (0.11 log units) above the measured number; measured number inside the range.
By their numbers in this assay, from the lowest: compounds 4, 3, 2 and 1 (each within the scatter of the next).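

Working from this assay, phenylsulfanyl has now been read directly in place of phenoxy on the aromatic carbon next to the ring nitrogen, and a 1.4-fold lower number from compound 3 to compound 4 (0.13 log units; within the scatter) shows no difference that can be separated from the scatter. For the compounds shown here, exchanging phenoxy for a sulfur-linked group therefore gives a flat step in both pairs at hand, since a 1.0-fold lower number from compound 1 to compound 2 (0.01 log units; within the scatter) is also within the scatter, and no compound here goes against this, although the pattern rests on these two pairs alone. No measurement on hand bears on what lies behind either step.

From the compounds shown here alone, it remains open whether an amine or a carboxylic acid on this aromatic carbon, or a phenyl group carried on a longer chain, would give a step beyond the scatter. Going by these compounds, it is equally open whether phenylsulfanyl would read the same on the core of compound 1, where the same pieces are joined differently.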